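Thiazole acetic acids: pyridin-4-yl for furan-2-yl at the aryl carbon

The source may report more compounds than this note shows. Statements on the series, on what has been measured and on what is new or still open speak of the compounds shown alone.

Measured so far:
compound 1 `CCC(c1ccccc1)c1nc(-c2ccc(Cl)cc2)c(CC(=O)O)s1`, 190 nM
compound 2 `O=C(O)Cc1sc(C(c2ccc(F)cc2)c2ccc(F)cc2)nc1-c1ccco1`, 18 nM

In an in vitro assay on HEK385-7 cells for displacement of a labelled ligand from prostaglandin D2 receptor 2 (Homo sapiens) (on this read-out higher numbers stand for weaker inhibition and lower numbers for stronger inhibition), compound 2 gives the lower of the two numbers; compound 1 gives 190 nM, a gap beyond the usual scatter. The two compounds differ in several places at once, so no single change can be read from that gap.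

Compound 3 `O=C(O)Cc1sc(C(c2ccc(F)cc2)c2ccc(F)cc2)nc1-c1ccncc1` keeps everything in compound 2 except one group: pyridin-4-yl in place of furan-2-yl on an aromatic carbon. Among the compounds with values here, nothing measured so far tests a change of this kind on the shared core.

Within the data shown here, with no step of this kind available, the expectation for compound 3 rests on compound 2 alone, and the estimate a 2.2-fold higher number from compound 2 to compound 3 (0.35 log units; beyond the scatter) is set as a modest weakening, close to the scatter. Compound 3 is thus estimated at 40 nM, with a range of 10 nM to 160 nM.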

Compound 3, half-maximal inhibitory concentration: 5.3 nM
The estimate for compound 3 lay 7.5-fold (0.88 log units) above the measured number, and the stated range ends above it.
By their numbers in this assay, from the lowest: compound 3; then compound 2; then compound 1.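

In this assay, within the data shown here, the aromatic carbon next to the ring nitrogen accepts a six-membered aromatic ring in place of a five-membered one without loss: pyridin-4-yl for furan-2-yl gives a 3.4-fold lower number from compound 2 to compound 3 (0.53 log units; beyond the scatter), the first single-place step on the shared core. The counted hydrogen-bond donors and acceptors are the same in both groups, so those counts do not separate them. Nothing available accounts for the size or direction of this step.

From the compounds shown here alone, whether the step follows the ring nitrogen or the larger ring stays open, and phenyl or pyridin-3-yl at this carbon would help separate the two. Also open, going by these compounds, is whether a step of this kind would carry over to the core of compound 1.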